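The source may hold more compounds than are shown below. What is called first, only, known or untested is meant among the compounds shown, and "the series" means these compounds.

Compound 1 `O=C(Nc1cccc([N+](=O)[O-])c1)N1CCN(S(=O)(=O)c2sccc2-c2ccccc2Oc2ccc(O)c(O)c2)CC1` gives 4500 nM in a functional assay on HL-60 cells (Homo sapiens) for inhibition, read by CCK-8 assay, with a stated time of 48 h; a higher number here means a weaker inhibitor, a lower number a stronger inhibitor. Compound 2 `O=[N+]([O-])c1ccc(NC(=S)N2CCN(S(=O)(=O)c3sccc3-c3ccccc3Oc3ccc(O)c(O)c3)CC2)cc1` gives 5300 nM in this assay. For the measured compounds named here, of the two numbers so far compound 2 carries the larger, though the single step of a 1.2-fold higher number from compound 1 to compound 2 (0.07 log units; within the scatter) does not separate it from compound 1. Compound 3 `COc1ccc(Oc2ccccc2-c2ccsc2S(=O)(=O)N2CCN(C(=S)Nc3ccc([N+](=O)[O-])cc3)CC2)cc1OC` differs from compound 2 by 3,4-dimethoxyphenyl in place of 3,4-dihydroxyphenyl on an oxygen on an aromatic ring. Going by the values given here, the one measured step alters the group on the amine nitrogen in a ring, not the 3,4-dihydroxyphenoxy side, so no measured step bears on this change. The expectation is therefore set at no step beyond the scatter, a 1.1-fold higher number from compound 2 to compound 3 (0.05 log units; within the scatter), with a wide range. Compound 3 is estimated at 6000 nM, between 2500 nM and 15000 nM in this assay.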

Compound 3, half-maximal inhibitory concentration: > 50000 nM
Compound 3: no number, only a limit; the forecaster's own chance of this, stated with the estimate: 10%; middle value at least 8.3-fold (0.92 log units) away from the limit.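

For the compounds shown here, exchanging 3,4-dihydroxyphenyl for 3,4-dimethoxyphenyl on an oxygen on an aromatic ring gives an at least 9.4-fold higher number from compound 2 to compound 3 (0.97 log units; beyond the scatter), the only step so far beyond the scatter, whereas the earlier change on the amine nitrogen in a ring gave a 1.2-fold higher number from compound 1 to compound 2 (0.07 log units; within the scatter). Compound 3 stands at a limit, not a number, in this assay: the limit of > 50000 nM in this assay, at which 1 of the 3 values shown sits. The 3,4-dihydroxyphenoxy side is therefore sensitive to substitution in this series.

As far as these compounds go, whether both hydroxy groups are needed stays open, as does whether the loss follows from removing them or from adding the methyl groups. A phenyl carrying one hydroxy and one methoxy group, or an amino group in place of hydroxy, would bear on this.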